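A few compounds are considered here, and "the series" means these few. Any claim that something is new, unique, unknown or untested is made for them only; others in the source may bear on it.

Three compounds built on one shared core were tested in an ADME assay on CCRF-CEM cells (Homo sapiens) for cytotoxicity, with a stated time of 5 days; on this read-out lower numbers stand for stronger inhibition and higher numbers for weaker inhibition. Compound 1 `CNc1nc(Cl)nc2c1ncn2[C@H]1C[C@H](N=[N+]=[N-])[C@@H](CO)O1` gave only the assay limit, > 100000 nM, rather than a number. Compound 2 `[N-]=[N+]=N[C@H]1C[C@H](n2cnc3c(NCCO)nc(N)nc32)O[C@@H]1CO` likewise reached only the limit of > 100000 nM. Compound 3 `COc1nc(N)c2ncn([C@H]3C[C@H](N=[N+]=[N-])[C@@H](CO)O3)c2n1` also stopped at the limit, > 100000 nM. Compound 2 therefore stands exactly where every measured compound stands, at the limit of > 100000 nM in this assay, at which 3 of the 3 values shown sit, with no value below it to set it apart from the others.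

Compound 4 `[N-]=[N+]=N[C@H]1C[C@H](n2cnc3c(NC4CC4)nc(N)nc32)O[C@@H]1CO` has not yet been measured. It differs from compound 2 in one place: cyclopropyl in place of 2-hydroxyethyl on a nitrogen on an aromatic ring. Within the data shown here, no two measured compounds differ by a single change, so the size of such a step cannot be read from the data in hand. Because every measured value sits at the limit of > 100000 nM in this assay, at which 3 of the 3 values shown sit, the expected step is a number no higher from compound 2 to compound 4 (the limit leaves the size open), which means no change beyond the scatter in this assay. Compound 4 is thus expected to give 100000 nM, within a range from 30000 nM to 300000 nM, most probably reported again as a limit rather than a number.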

Compound 4, half-maximal inhibitory concentration: > 100000 nM
Compound 4: only a limit was reported; the forecaster's own chance of this, stated with the estimate: 80%; the middle value sits exactly at the limit.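

Among these compounds, compound 2 and compound 4 each reached only a limit, and no step between them can be read for cyclopropyl in place of 2-hydroxyethyl. The compounds shown leave open whether any change to the shared core would give an actual number in this assay: the limit of > 100000 nM in this assay, at which 4 of the 4 values shown sit.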